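Compound 3: hydrogen in place of butyl

The compounds below may be only part of what the source reports. "The series", "measured", "known", "first", "only" and "open" are said of these compounds alone.

Measured in a functional assay on A549 cells (Homo sapiens) for inhibition; a lower number here means a stronger inhibitor, a higher number a weaker inhibitor:
- compound 1 `N#CC1CN1C(=O)Nc1ccc(Cl)c(Cl)c1`: 7500 nM
- compound 2 `CCCCNC(=O)N1CC1C#N`: 18000 nM

Compound 2, at 18000 nM, has the higher of the two numbers and is thus the weaker inhibitor. Compound 1, at 7500 nM, lies lower by a margin beyond the scatter. The two differ in more than one place, so no single change can be read from this pair.

Compound 3 `N#CC1CN1C(N)=O` is not yet measured in this assay. Its difference from compound 2 is hydrogen in place of butyl on an amide-type nitrogen. Within the data shown here, no measured pair shows the size of this change, and both measured compounds carry a substituent on that nitrogen. The estimate therefore rests on little and stays wide. A modest move towards a higher number, meaning a weaker inhibitor, is expected, with the estimated step of a 2.2-fold higher number from compound 2 to compound 3 (0.35 log units; beyond the scatter). For compound 3 the expected value is 40000 nM, with an estimated range from 12000 nM to 130000 nM.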

Compound 3, half-maximal inhibitory concentration: > 280000 nM
Compound 3: a limit, no number (the forecaster's own chance of this, stated with the estimate: 15%); middle value at least 7.0-fold (0.84 log units) away from the limit.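

In this assay compound 3 gives > 280000 nM, which is a limit of the assay and not a number, and this is the only reading of that kind among the compounds shown: the limit of > 280000 nM in this assay, at which 1 of the 3 values shown sits.

Hydrogen in place of butyl on the amide-type nitrogen is the first change at this position that can be read on its own, and it gives an at least 15-fold higher number from compound 2 to compound 3 (1.19 log units; beyond the scatter), a large step beyond the scatter. The substituent on this nitrogen therefore counts for much in this series: the two compounds that carry one, butyl in compound 2 and the dichlorophenyl group in compound 1, both give numbers, whereas the unsubstituted compound 3 reaches the limit.

The limit leaves the full size of the step open, so the result fixes only its lower bound and gives no true value for compound 3. As far as these compounds go, whether a small group such as methyl already recovers a measurable number on this nitrogen, or whether a longer chain such as octyl or a benzyl group moves it further towards a stronger inhibitor, stays open.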